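Shifting the chain amine on a benzyloxy flavone

A few compounds are considered here, and "the series" means these few. Any claim that something is new, unique, unknown or untested is made for them only; others in the source may bear on it.

Of the compounds shown here, two have been measured in a functional assay on BCG823 cells (Homo sapiens) for antiproliferative activity, read by MTT assay, with a stated time of 48 h; a lower number here means a stronger inhibitor, a higher number a weaker inhibitor. Compound 1 `CN1CCN(CCCCOc2c(O)cc3oc(-c4ccccc4)cc(=O)c3c2O)CC1` gives 82900 nM in this assay. Compound 2 `CCN(CC)CCCCOc1c(OCc2ccccc2)cc2oc(-c3ccccc3)cc(=O)c2c1O` gives 4200 nM in this assay, the lower of the two numbers; compound 1 sits a good deal higher, well beyond the scatter, though the two compounds differ in more than one place, so no single change can be read from that gap. The next compound, compound 3 `CN1CCN(CCCOc2c(OCc3ccccc3)cc3oc(-c4ccccc4)cc(=O)c3c2O)CC1`, is still to be measured in this assay. It differs from compound 2 in one place: 4-methylpiperazin-1-yl in place of (diethylamino)methyl on a saturated chain carbon, three bonds along the chain from an oxygen on an aromatic ring. Since compound 1, which also carries the 4-methylpiperazin-1-yl group, gave the weaker 82900 nM, a modest loss against compound 2 is expected, and the step of a 2.4-fold higher number from compound 2 to compound 3 (0.38 log units; beyond the scatter) is estimated to be small to moderate. Compound 3 is therefore expected to give about 10000 nM, within a range of 3000 nM to 40000 nM.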

Compound 3, half-maximal inhibitory concentration: 4100 nM
For compound 3 the middle estimate is 2.4-fold (0.39 log units) above the measured one; low and high end bracket the measured number.
By their numbers in this assay, from the lowest: compounds 3 and 2 (each within the scatter of the next); then compound 1.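

In this assay, the change read as a 1.0-fold lower number from compound 2 to compound 3 (0.01 log units; within the scatter) leaves compound 2 and compound 3 within the scatter of each other. Read one bond further out, this change is 4-(diethylamino)butyl to 3-(4-methylpiperazin-1-yl)propyl, so the single step alters both the amine and the chain that carries it, and the first one-place comparison in this series shows no separation in this read-out between these two chain ends on the benzyloxy-bearing core. No measured information is available to explain this result.

The compounds shown do not separate the part played by the amine from that of the chain length. A 4-(4-methylpiperazin-1-yl)butyl chain on the same core would address this, while a morpholine or a primary amine at the chain end would test how far this level result extends.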